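This account rests on a few compounds, and the source may have more. Where it says the series, first, only, none or still open, it means among the compounds named here.

Working notes on the series.

Compound 2 `COc1ccc2c(=O)c(/C=C/C(=O)NCc3ccccc3)coc2c1` stands at the bottom of what has been seen so far: in a functional assay (QGY7701 cells, Homo sapiens) for inhibition, read by MTT assay, with a stated time of 48 h (a lower number here means a stronger inhibitor, a higher number a weaker inhibitor), compound 2 gives only a limit, > 100000 nM, and no number. The same is true of compound 1 `COc1ccc2c(=O)c(/C=C/C(=O)Nc3cccc(C)c3)coc2c1`, which in this assay gives the limit > 100000 nM. Only compound 3 `COc1ccc2c(=O)c(/C=C/C(=O)Nc3ccccc3OC)coc2c1` returns a number, 17600 nM. Of the three values shown, (the limit of > 100000 nM in this assay, at which 2 of the 3 values shown sit), so two of the three are limits rather than numbers.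

The change to be judged is 4-chlorophenyl in place of benzyl on an amide-type nitrogen, giving compound 4 `COc1ccc2c(=O)c(/C=C/C(=O)Nc3ccc(Cl)cc3)coc2c1`.

Going by the values given here, two measured steps bear on it. The step of an at least 5.6-fold lower number from compound 2 to compound 3 (0.75 log units; beyond the scatter) shows that exchanging the benzyl on the amide-type nitrogen for a ring bearing a 2-methoxyphenyl brings the value down to a readable number. The step that the two limits leave unreadable from compound 1 to compound 2 cannot be read, since both values are limits. The step of an at least 5.6-fold lower number from compound 1 to compound 3 (0.75 log units; beyond the scatter) shows that not every aryl substituent on that nitrogen sits where compound 3 does; the 3-methylphenyl of compound 1 stays at the limit. Whether a 4-chlorophenyl on that nitrogen behaves like the 2-methoxyphenyl of compound 3 or like the 3-methylphenyl of compound 1 is not shown by these three compounds. The expectation for compound 4 is placed between those two outcomes.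

The expected step is an at least 2.0-fold lower number from compound 2 to compound 4 (0.30 log units; that floor lies within the scatter). For compound 4 the estimate in this assay is 50000 nM, with a range from 12000 nM to 200000 nM.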

Compound 4, half-maximal inhibitory concentration: > 100000 nM
Compound 4: only a limit was reported (the forecaster's own chance of this, stated with the estimate: 45%); at least 2.0-fold (0.30 log units) between middle value and limit.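

In this assay compound 4 gives > 100000 nM, which is a limit and not a number. Exchanging the 2-methoxyphenyl for 4-chlorophenyl on the amide-type nitrogen gives an at least 5.6-fold higher number from compound 3 to compound 4 (0.75 log units; beyond the scatter), so a second aryl group, besides the 3-methylphenyl of compound 1, fails to return a readable number, and among the compounds shown only the 2-methoxyphenyl does. The steps from compound 2 to compound 4 and from compound 1 to compound 4 cannot be read, as both ends of each are limits, and the series now rests mostly on one floor: the limit of > 100000 nM in this assay, at which 3 of the 4 values shown sit.

Open, as far as these compounds go, is how a 2-chlorophenyl or a 4-methoxyphenyl on the amide-type nitrogen would read, which would tell whether the number of compound 3 goes with the methoxy group or with its place on the ring. Also open, from the compounds shown here alone, are how far the compounds at the limit lie from one another and how a phenyl ring carrying an amine or a carboxylic acid on that nitrogen would read.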